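This account rests on a few compounds, and the source may have more. Where it says the series, first, only, none or still open, it means among the compounds named here.

In a functional assay on L1210 cells (Mus musculus) for inhibition, read by MTT assay (a lower number here means a stronger inhibitor, a higher number a weaker inhibitor), compound 2 `N#CC1CN1C(=O)Nc1ccc([N+](=O)[O-])cc1` gives 2600 nM, the lowest of the two numbers recorded; compound 1 `CCCCNC(=O)N1CC1C#N` gives 12000 nM, a gap beyond the usual scatter. Compound 3 `N#CC1CN1C(=O)Nc1ccc(S(N)(=O)=O)cc1` differs from compound 2 by sulfamoyl in place of nitro on an aromatic carbon. Among the compounds with values here, no measured pair shows this change, so the size of the step in this assay is open. Compound 3 is expected to give about 4000 nM in this assay, within 1300 nM to 12000 nM. That estimate means a step of a 1.5-fold higher number from compound 2 to compound 3 (0.19 log units; within the scatter), expected to stay close to the scatter.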

Compound 3, half-maximal inhibitory concentration: > 38000 nM
Compound 3 was reported as a limit; the forecaster's own chance of this, stated with the estimate: 5%; at least 9.5-fold (0.97 log units) between middle value and limit.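

In this assay, sulfamoyl in place of nitro on an aromatic carbon is far from a neutral swap, giving an at least 14-fold higher number from compound 2 to compound 3 (1.16 log units; beyond the scatter). The value of compound 3, > 38000 nM, is a limit of the assay and not a number. Within the data shown here, the position para to a group of 8 heavy atoms, which the earlier compounds did not probe, therefore responds strongly to the group placed there.

Going by these compounds, how an amine or a carboxylic acid would fare at this position remains open. So does how far the true value of compound 3 lies beyond its limit.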